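Amino to fluoro on two related cores

The source may report more compounds than this note shows. Statements on the series, on what has been measured and on what is new or still open speak of the compounds shown alone.

Measured in a functional assay (Homo sapiens) for inhibition; a higher number here means a weaker inhibitor, a lower number a stronger inhibitor:
compound 1 `CC(=O)OC(C)n1cnc2c(S)nc(N)nc21` gives 25000 nM.
compound 2 `CC(=O)OCCOn1cnc2c(S)nc(N)nc21` gives > 500000 nM, which is a limit of the assay and not a number.
compound 3 `CC(=O)OC(C)n1cnc2c(S)nc(F)nc21` gives > 500000 nM, again a limit of the assay.

The difference between the cores of compound 1 and compound 2 is not broken down here. Within the core of compound 1, the change fluoro in place of amino on an aromatic carbon produced the step of an at least 20-fold higher number from compound 1 to compound 3 (1.30 log units; beyond the scatter). Compound 2 already stands at the limit of > 500000 nM in this assay, at which 2 of the 3 values shown sit. Compound 4 `CC(=O)OCCOn1cnc2c(S)nc(F)nc21` carries the same change made on compound 2, namely (fluoro in place of amino on an aromatic carbon). Because compound 2 rests at the limit of > 500000 nM in this assay, at which 2 of the 3 values shown sit, and the same change on compound 1 gave an at least 20-fold higher number from compound 1 to compound 3 (1.30 log units; beyond the scatter), compound 4 is expected to report only a limit again, a step that the limit leaves unreadable from compound 2 to compound 4. The estimate for compound 4 is 1000000 nM, between 500000 nM and 5000000 nM.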

Compound 4, half-maximal inhibitory concentration: > 500000 nM
Compound 4 was reported as a limit (the forecaster's own chance of this, stated with the estimate: 95%); the middle value lies beyond the limit too.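

Among these compounds, compound 2 and compound 4 both report only a limit, so no step between them can be read. As far as these compounds go, whether fluoro in place of amino acts on the core of compound 2 as on that of compound 1 stays open.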